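Capping the Ring Nitrogen of a Biphenyl Amide

This account rests on a few compounds, and the source may have more. Where it says the series, first, only, none or still open, it means among the compounds named here.

Two compounds share a biphenyl amide attached to a fused two-ring core. Compound 1 `CN1CCCc2cc(NC(=O)c3ccc(-c4ccccc4)cc3)ccc21` carries a methyl on the ring nitrogen of the non-aromatic ring, and in a functional assay for antagonist activity at transient receptor potential cation channel subfamily V member 1 (Homo sapiens), read by FLIPR and calcium flux (on this read-out higher numbers stand for higher potency (the scale is a negative logarithm) and lower numbers for lower potency), compound 1 gives 7.1. Compound 2 `O=C(Nc1ccc2c(c1)NCCC2)c1ccc(-c2ccccc2)cc1` has a hydrogen on that nitrogen instead, and in this assay compound 2 gives 7.7, the higher of the two numbers, and the gap to compound 1 lies beyond the scatter of repeated measurements.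

Compound 3 `COCC(=O)N1CCCc2ccc(NC(=O)c3ccc(-c4ccccc4)cc3)cc21` is the next step from compound 2: (methoxymethyl)carbonyl in place of hydrogen on a nitrogen on an aromatic ring in a ring. The ring nitrogen that is bare in compound 2 thus receives a larger group than the methyl of compound 1. Nothing measured shows this exact change, so the outcome rests on a single comparison. A loss is expected, because compound 1 with its methyl gives 7.1, and the step from compound 2 is estimated as a number 0.80 log units lower from compound 2 to compound 3 (beyond the scatter). Compound 3 is therefore expected to reach about 6.9 in this assay, with a likely range from 6.2 to 7.6.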

Compound 3, negative logarithm of the antagonist equilibrium constant: 7.2
Compound 3: the middle estimate sits 0.30 log units below what was measured, and the stated range covers the measured number.
By their numbers in this assay, from the lowest: compounds 1 and 3 (each within the scatter of the next); then compound 2.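

Among these compounds, compound 1 differs from compound 2 in more than one place, so only this new pair isolates the nitrogen of the six-membered non-aromatic ring, and in this assay placing (methoxymethyl)carbonyl there in place of hydrogen gives a number 0.50 log units lower from compound 2 to compound 3 (beyond the scatter). This shows that the hydrogen on this nitrogen can be replaced by a group of 5 heavy atoms with a real but modest loss rather than a collapse in potency, since compound 3 still gives 7.2. No measurement shown explains the loss.

A single group at this nitrogen cannot separate the contribution of the carbonyl from that of the methoxy end, so a plain acetyl group would be the natural comparison, while a longer chain would show how the number changes as the group grows. Groups ending in an amine or a carboxylic acid are also open, and whether any group on this nitrogen can match or pass compound 2 remains unknown.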